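This account rests on a few compounds, and the source may have more. Where it says the series, first, only, none or still open, it means among the compounds named here.

Compound 1 `CCCCCCCn1nc(-c2ccccc2)c(-c2ccccc2)cc1=O` gives 86000 nM in an assay on microsomes from liver for inhibition of sterol O-acyltransferase 1 (Rattus norvegicus); a higher number here means a weaker inhibitor, a lower number a stronger inhibitor. Compound 3 `CCCCCCOc1cc(-c2ccccc2)c(-c2ccccc2)nn1` gives 72000 nM in this assay. Compound 2 `O=c1cc(-c2ccccc2)c(-c2ccccc2)nn1C1CCCCC1` gives only a limit of the assay, > 300000 nM.

Of the two plain numbers, compound 3 has the lowest, and compound 1 is nearest to it, within the usual scatter. Compound 4 `O=C(O)CCCCCSc1cc(-c2ccccc2)c(-c2ccccc2)nn1` differs from compound 3 in one place: (5-carboxypentyl)sulfanyl in place of hexyloxy on an aromatic carbon. Within the data shown here, the one measured step, an at least 3.4-fold higher number from compound 1 to compound 2 (0.54 log units; beyond the scatter), changes a group on an aromatic nitrogen, whereas compound 4 changes a group on an aromatic carbon, so no measured step bears directly on this change. Compound 4 is therefore expected to sit close to compound 3, with a wide range. The expected step is a 1.0-fold lower number from compound 3 to compound 4 (0.01 log units; within the scatter) in this assay. The estimate for compound 4 is 70000 nM, from 15000 nM to 300000 nM.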

Compound 4, half-maximal inhibitory concentration: > 300000 nM
Compound 4: a limit, no number (the forecaster's own chance of this, stated with the estimate: 25%); middle value at least 4.2-fold (0.63 log units) away from the limit.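

Replacing hexyloxy with (5-carboxypentyl)sulfanyl gives an at least 4.1-fold higher number from compound 3 to compound 4 (0.61 log units; beyond the scatter) in this assay, so the group on this aromatic carbon does matter, which the earlier step on an aromatic nitrogen could not show. The value of compound 4 is a limit and not a number, so the full size of the step stays unknown: the limit of > 300000 nM in this assay, at which 2 of the 4 values shown sit.

The compounds shown leave open which part of the change counts, the sulfur link or the carboxylic acid at the chain end. A plain hexylsulfanyl group, or an amine at the chain end, would bear on that question.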